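This account rests on a few compounds, and the source may have more. Where it says the series, first, only, none or still open, it means among the compounds named here.

Compound 1 `O=C1/C(=C/c2ccncc2)CN(S(=O)(=O)c2ccc(C(F)(F)F)cc2)C/C1=C\c1ccccc1F`: 9500 nM
Compound 2 `O=C1/C(=C/c2ccncc2)CN(S(=O)(=O)c2ccc(F)cc2)C/C1=C\c1ccccc1F`: 9100 nM

In a functional assay on QGY-7703 cells (Homo sapiens) for cytotoxicity, read by MTT assay, with a stated time of 24 h (on this read-out lower numbers stand for stronger inhibition and higher numbers for weaker inhibition), compound 2 gives 9100 nM, and compound 1 gives 9500 nM. The two values lie within the scatter of each other, so compound 2 stands level with compound 1. Compound 3 `N#Cc1ccc(S(=O)(=O)N2C/C(=C\c3ccncc3)C(=O)/C(=C/c3ccccc3F)C2)cc1` keeps the core of compound 2 and makes one change: cyano in place of fluoro on an aromatic carbon. In words, cyano takes the place of fluoro on an aromatic carbon, para to a large group.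

Among the compounds with values here, only one measured step bears on this, the swap of trifluoromethyl for fluoro on an aromatic carbon, a 1.0-fold lower number from compound 1 to compound 2 (0.02 log units; within the scatter). Within the data shown here, that step was too small to separate from the scatter, although no cyano compound has been measured yet. No shift beyond the scatter is therefore expected in this assay, and the expected step is a 1.0-fold lower number from compound 2 to compound 3 (0.00 log units; within the scatter). For compound 3 the estimated value is 9000 nM, with an expected range from 4500 nM to 18000 nM.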

Compound 3, half-maximal inhibitory concentration: 8500 nM
Compound 3: middle estimate off by 1.1-fold (0.02 log units), on the high side; low and high end bracket the measured number.
By their numbers in this assay, from the lowest: compounds 3, 2 and 1 (each within the scatter of the next).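

In this assay this position, para to a large group, has now carried a third group, and the read-out still does not separate them. Cyano in place of fluoro gives a 1.1-fold lower number from compound 2 to compound 3 (0.03 log units; within the scatter) and cyano in place of trifluoromethyl gives a 1.1-fold lower number from compound 1 to compound 3 (0.05 log units; within the scatter), so a group with a triple bond and a hydrogen-bond acceptor stands level with both halogen-bearing groups. No measurement shown here offers a reason for this flat result.

As far as these compounds go, all three compounds keep the same shared core, so it remains open whether any group at this position can move the number beyond the scatter. An amine, a carboxylic acid or a longer chain in place of cyano would test this, and a step beyond the scatter would show that the position matters in this assay.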